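Moving a chlorine on the benzyl group of compound 2

A few compounds are considered here, and "the series" means these few. Any claim that something is new, unique, unknown or untested is made for them only; others in the source may bear on it.

Measured compounds:
compound 1, `Cc1ccc(S(=O)(=O)N(Cc2nnc(Cc3ccc(N(C)C)cc3)o2)c2cccc(Cl)c2C)cc1`, 12.6 nM
compound 2, `Cc1ccc(S(=O)(=O)N(Cc2nnc(Cc3c(Cl)cccc3Cl)o2)c2cccc(Cl)c2C)cc1`, 63.1 nM

In an assay on CHO cells for displacement of a labelled ligand from prostaglandin E2 receptor EP1 subtype (Homo sapiens) (a lower number here means a stronger inhibitor, a higher number a weaker inhibitor), compound 2 gives 63.1 nM, the higher of the two numbers measured. Among the measured compounds shown here, its one neighbour is compound 1, which gives 12.6 nM; the step of a 5.0-fold higher number from compound 1 to compound 2 (0.70 log units; beyond the scatter) is beyond the scatter. Compound 3, `Cc1ccc(S(=O)(=O)N(Cc2nnc(Cc3ccc(Cl)cc3Cl)o2)c2cccc(Cl)c2C)cc1`, is unmeasured. It differs from compound 2 by 2,4-dichlorophenyl in place of 2,6-dichlorophenyl on a saturated chain carbon bound to an aromatic carbon, so both chlorines stay on the ring and only one of them moves. For the measured compounds named here, the single measured step, from compound 1 to compound 2, exchanges the whole substituted phenyl for another and does not test a rearrangement of two chlorines on the same ring; no measured pair bears directly on this change. Compound 3 is therefore expected to sit close to compound 2, with the step of a 1.3-fold lower number from compound 2 to compound 3 (0.10 log units; within the scatter) expected to lie within the scatter. The estimate for compound 3 in this assay is 50 nM, with a range from 15 nM to 200 nM.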

Compound 3, half-maximal inhibitory concentration: 63.1 nM
For compound 3 the middle estimate is 1.3-fold (0.10 log units) below the measured one; the measured number falls inside the stated range.
By their numbers in this assay, from the lowest: compound 1; then compounds 2 and 3 (each within the scatter of the next).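

In this assay, the change to 2,4-dichlorophenyl in place of 2,6-dichlorophenyl on a saturated chain carbon bound to an aromatic carbon gives no change at the digits printed from compound 2 to compound 3 (within the scatter), so moving one of the two chlorines on this ring leaves the number unchanged. Against the 4-(dimethylamino)phenyl group, the new arrangement gives a 5.0-fold higher number from compound 1 to compound 3 (0.70 log units; beyond the scatter), the same size as a 5.0-fold higher number from compound 1 to compound 2 (0.70 log units; beyond the scatter), so the gap to that group holds for both chlorine arrangements. Nothing available here accounts for the lack of change when the chlorine moves.

Going by these compounds, it remains open whether that gap follows the dimethylamino group or the chlorines, as the two differ together in each step. Also open, on these data alone, is what an unsubstituted phenyl, a primary amine or a carboxylic acid would give at this position.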